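This account rests on a few compounds, and the source may have more. Where it says the series, first, only, none or still open, it means among the compounds named here.

Measured in an ADME assay on S9 fraction from liver (Rattus norvegicus) for metabolic stability, read by LC-MS, using NADPH, with a stated time of 30 min; on this read-out higher numbers stand for a more stable compound and lower numbers for a less stable compound:
compound 1 `CCCCCCCCc1ccc(OCC(=O)Cn2cnnn2)cc1` gives 22%
compound 2 `CCCCCCCCc1ccc(OCC(=O)Cn2nnc(-c3cccc(S(=O)(=O)N(C)C)c3)n2)cc1` gives 9%
compound 3 `CCCCCCCCc1ccc(OCC(=O)Cn2nnc(Cc3ccccc3)n2)cc1` gives < 5%, a limit of the assay

Compound 2 holds the lowest of the two numbers shown; compound 1 stands higher by a gap beyond the scatter. For compound 3 only a limit is recorded, (the limit of < 5% in this assay, at which 1 of the 3 values shown sits). Within the data shown here, the one measured change at the same place is a number at least 4 percentage points lower from compound 2 to compound 3 (that floor lies within the scatter), benzyl in place of 3-(dimethylsulfamoyl)phenyl on an aromatic carbon, and its floor lies within the scatter. Compound 4 `CCCCCCCCc1ccc(OCC(=O)Cn2nnc(-c3cccc(C(=O)O)c3)n2)cc1` differs from compound 2 by carboxy in place of dimethylsulfamoyl on an aromatic carbon. Among the measured compounds shown here, no measured step shares this change, so only a small move is expected, a number 3 percentage points higher from compound 2 to compound 4 (within the scatter). Compound 4 is therefore estimated to give 12%, between 5% and 28%.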

Compound 4, percent of the compound remaining: < 5%
Compound 4 was reported as a limit; the forecaster's own chance of this, stated with the estimate: 15%; middle value at least 7 percentage points from the limit.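

Carboxy in place of dimethylsulfamoyl on this aromatic carbon gives, in this assay, a number at least 4 percentage points lower from compound 2 to compound 4 (that floor lies within the scatter), so this change, like the earlier swap to benzyl, yields no number higher than that of compound 2. Compound 4 is recorded only as a limit, not a number, as is compound 3: the limit of < 5% in this assay, at which 2 of the 4 values shown sit. The step between these two compounds cannot be read.

On these data alone, whether the true drop from compound 2 exceeds the scatter remains open. So does how a methyl ester or an amine at this place would read.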